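The compounds below may be only part of what the source reports. "The series", "measured", "known", "first", "only" and "open" are said of these compounds alone.

In a physicochemical assay for pharmacokinetics (on this read-out higher numbers stand for a longer-lived compound and lower numbers for a shorter-lived compound), two compounds that share one core have been measured so far. Compound 1 `O=C(NCc1ccccc1)N1C(=O)c2ccccc2S1(=O)=O` gives 1.02 h, and compound 2 `O=C(NCC1CCCCC1)N1C(=O)c2ccccc2S1(=O)=O` gives 0.963 h. Within the data shown here, these two numbers lie within the usual scatter of repeated measurements, so compound 2 stands level with the only other measured compound. The next compound is compound 3 `O=C(NCc1cccs1)N1C(=O)c2ccccc2S1(=O)=O`, and the change is thiophen-2-yl in place of cyclohexyl on a saturated chain carbon bound to an amide-type nitrogen. In short, it has thiophen-2-yl in place of cyclohexyl on a saturated chain carbon bound to an amide-type nitrogen. Among the measured compounds shown here, one measured step bears on this, made at the same place with cyclohexyl in place of phenyl: a 1.1-fold lower number from compound 1 to compound 2 (0.02 log units; within the scatter). The incoming group is an aromatic ring, as phenyl is in compound 1, and exchanging that phenyl for cyclohexyl left this assay unchanged beyond the scatter. For the measured compounds named here, no measured compound carries thiophen-2-yl, so this comparison is only a rough guide, and no step beyond the scatter is expected. The estimated step is a 1.0-fold higher number from compound 2 to compound 3 (0.02 log units; within the scatter). For compound 3 the expected half-life is 1 h, with an estimated range from 0.55 h to 1.8 h.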

Compound 3, half-life: 0.365 h
The estimate for compound 3 lay 2.7-fold (0.44 log units) above the measured number; the measured number lies below the stated range.
By their numbers in this assay, from the lowest: compound 3; then compounds 2 and 1 (each within the scatter of the next).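

At this place, on a saturated chain carbon bound to an amide-type nitrogen, the choice of ring can move the number in this assay: thiophen-2-yl in place of cyclohexyl gives a 2.6-fold lower number from compound 2 to compound 3 (0.42 log units; beyond the scatter), and thiophen-2-yl in place of phenyl gives a 2.8-fold lower number from compound 1 to compound 3 (0.45 log units; beyond the scatter). The earlier step, a 1.1-fold lower number from compound 1 to compound 2 (0.02 log units; within the scatter), showed no separation between an aromatic and a non-aromatic six-membered ring, whereas this result shows that being aromatic does not settle the matter, since phenyl and thiophen-2-yl are both aromatic yet differ beyond the scatter. No measurement shown here gives a reason for the lower half-life of compound 3.

The compounds shown leave open whether the lower number goes with the sulfur atom, with the five-membered ring or with both, as thiophen-2-yl differs from phenyl in ring size and in carrying a hetero atom. They also do not tell how a furan-2-yl ring, with oxygen in place of sulfur, or a cyclopentyl ring, a five-membered ring of carbon only, would read at this place.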